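The compounds below may be only part of what the source reports. "The series", "measured", "known", "first", "only" and "open" are said of these compounds alone.

Working notes on the series, solubility.

Of the compounds shown here, three have been measured in a physicochemical assay for solubility; on this read-out lower numbers stand for lower solubility and higher numbers for higher solubility. Compound 1 `CNC(=O)c1ccc(-c2ccc3c(c2)C(C)(C)C(=O)N3c2ccc(C#N)c(OC)c2)cc1F` gives 9700 nM. Compound 2 `N#Cc1ncc(-n2c(=O)n(Cc3ccccc3)c3ccccc32)cc1C(F)(F)F` gives 5300 nM in this assay. Compound 3 `N#CCn1c(=O)n(-c2ccc(C#N)c(C(F)(F)F)c2)c2ccccc21` gives 18900 nM in this assay, which is the highest of the three numbers; the number of compound 1 lies within the usual scatter of it, while the number of compound 2 lies beyond the scatter and is clearly lower. Among the compounds with values here, no pair among the measured compounds differs in a single place, so no step can be read off directly.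

Compound 4 `Cc1ccc(-n2c(=O)n(-c3ccc(C#N)c(C(F)(F)F)c3)c3ccccc32)cc1` has not yet been measured. It is derived from compound 3 by the change 4-methylphenyl in place of cyanomethyl on an aromatic nitrogen. Within the data shown here, no comparable step is available among the measured compounds, so the expectation rests on the change itself and on the position of compound 3 at the top of the present numbers. For compound 4 the number in this assay is expected to move downward by a step of a 6.3-fold lower number from compound 3 to compound 4 (0.80 log units; beyond the scatter), beyond the scatter. The estimate for compound 4 in this assay is 3000 nM, with a range from 900 nM to 9000 nM.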

Compound 4, solubility: 790 nM
The estimate for compound 4 lay 3.8-fold (0.58 log units) above the measured number; the whole stated range lies above it.
By their numbers in this assay, from the lowest: compound 4; then compounds 2, 1 and 3 (each within the scatter of the next, the first and the last beyond it).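

Within the data shown here, on the aromatic nitrogen, 4-methylphenyl in place of cyanomethyl gives a 24-fold lower number from compound 3 to compound 4 (1.38 log units; beyond the scatter) in this assay, the first change that can be read in one place. The earlier compounds shown here, none of which differ from each other in a single place, could not show that this position answers so strongly to the group it carries. The change also has several parts: cyanomethyl, with 3 heavy atoms, a triple bond and a hydrogen-bond acceptor, leaves, while 4-methylphenyl, with 7 heavy atoms, a six-membered aromatic ring of carbon only and no hydrogen-bond acceptor, enters, and no measurement at hand bears on why the number falls.

Open, as far as these compounds go, is which part of the change carries the step: the loss of the nitrile, the entry of the aromatic ring, the methyl on that ring, or the larger heavy-atom count, since a single pair cannot separate these. Groups such as a plain ethyl chain, an unsubstituted phenyl, or a phenyl bearing a carboxylic acid or an amine on the same nitrogen would divide that step into smaller parts, and whether it carries over to other cores also remains open.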